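Notes on the shared core: from compound 3 to compound 4

This account rests on a few compounds, and the source may have more. Where it says the series, first, only, none or still open, it means among the compounds named here.

Measured in a functional assay on CHO cells for antagonist activity at prostaglandin E2 receptor EP1 subtype (Homo sapiens), read by FLIPR and calcium flux; a lower number here means a stronger inhibitor, a higher number a weaker inhibitor:
compound 1 `CCc1ccccc1N(Cc1nnc(Cc2ccc(OC)cc2)o1)S(=O)(=O)c1ccc(C)cc1`: 631 nM
compound 2 `COc1ccc(Cc2nnc(CN(c3cccc(Cl)c3C)S(=O)(=O)c3ccc(C)cc3)o2)cc1`: 39.8 nM
compound 3 `Cc1ccc(S(=O)(=O)N(Cc2nnc(Cc3ccccc3F)o2)c2cccc(Cl)c2C)cc1`: 631 nM

Compound 3 is level with compound 1 at the digits shown, and the two together give the highest numbers of the three. Within the data shown here, the only step reaching compound 3 that goes beyond the scatter is a 16-fold higher number from compound 2 to compound 3 (1.20 log units; beyond the scatter), a large one.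

Compound 4 `Cc1ccc(S(=O)(=O)N(Cc2nnc(Cc3c(Cl)cccc3Cl)o2)c2cccc(Cl)c2C)cc1` differs from compound 3 by 2,6-dichlorophenyl in place of 2-fluorophenyl on a saturated chain carbon bound to an aromatic carbon. Among the measured compounds shown here, the one measured step at this place, a 16-fold higher number from compound 2 to compound 3 (1.20 log units; beyond the scatter), exchanged 4-methoxyphenyl for 2-fluorophenyl and was large; no measured pair covers 2,6-dichlorophenyl, so the data fix neither direction nor size for this change. The expectation for compound 4 in this assay is therefore a step of a 1.0-fold lower number from compound 3 to compound 4 (0.00 log units; within the scatter), within the scatter. Compound 4 is estimated at 630 nM, in the range 200 nM to 2000 nM.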

Compound 4, inhibition constant: 501 nM
Estimate against measurement, compound 4: 1.3-fold (0.10 log units) above; low and high end bracket the measured number.
By their numbers in this assay, from the lowest: compound 2; then compounds 4, 1 and 3 (each within the scatter of the next).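

The change to 2,6-dichlorophenyl gives a 1.3-fold lower number from compound 3 to compound 4 (0.10 log units; within the scatter) in this assay, so this second replacement at this place also fails to recover the number of compound 2. Measured against 4-methoxyphenyl, it gives a 13-fold higher number from compound 2 to compound 4 (1.10 log units; beyond the scatter), and among compounds 2, 3 and 4, only compound 2 keeps the low number. No measurement offered here accounts for this difference.

From the compounds shown here alone, it remains open how an unsubstituted phenyl, or a group such as an amine or a carboxylic acid, would read at this place.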